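The compounds below may be only part of what the source reports. "The series", "measured", "known", "first", "only" and "open" are said of these compounds alone.

In an ADME assay on cells (Hepatocyte, Rattus norvegicus) for pharmacokinetics, read by LC-MS, with a stated time of 90 min, tested at 1 uM (on this read-out higher numbers stand for fast clearance and lower numbers for slow clearance), compound 1 `CCN(C(=O)OC)c1c(N)nc(-c2nn(Cc3ccccc3F)c3ncccc23)nc1N` gives 11.7 mL/min/kg and stands in the middle of the three measured numbers: compound 2 `COC(=O)N(Cc1ccccc1F)c1c(N)nc(-c2nn(Cc3ccccc3F)c3ncccc23)nc1N` gives 53.3 mL/min/kg on the high side and compound 3 `COC(=O)Nc1c(N)nc(-c2nn(Cc3ccccc3F)c3ncccc23)nc1N` gives 1.67 mL/min/kg on the low side. Compound 4 `Nc1nc(-c2nn(Cc3ccccc3F)c3ncccc23)nc(N)c1NC(=O)OC1COC1` is still unmeasured and differs from compound 1 on an aromatic carbon ((((oxetan-3-yl)oxy)carbonyl)amino in place of ethyl(methoxycarbonyl)amino on an aromatic carbon). Going by the values given here, two measured steps bear on it: the modest 7.0-fold lower number from compound 1 to compound 3 (0.85 log units; beyond the scatter) on replacing ethyl with hydrogen, and the large 32-fold lower number from compound 2 to compound 3 (1.50 log units; beyond the scatter) on replacing 2-fluorobenzyl with hydrogen, both beyond the scatter. Among the compounds with values here, compound 4 keeps a hydrogen on the amide-type nitrogen like compound 3 (1.67 mL/min/kg), but its (oxetan-3-yl)oxy group has no measured precedent, so a modest drop is expected in this assay. The expected step is a 3.3-fold lower number from compound 1 to compound 4 (0.52 log units; beyond the scatter) in this estimate. Compound 4 is estimated at 3.5 mL/min/kg with a range from 1.2 mL/min/kg to 10 mL/min/kg in clearance.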

Compound 4, clearance: 1.67 mL/min/kg
The estimate for compound 4 lay 2.1-fold (0.32 log units) above the measured number, within the range that was stated.
By their numbers in this assay, from the lowest: compounds 3 and 4 (each within the scatter of the next); then compound 1; then compound 2.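

Replacing methyl with oxetan-3-yl on the oxygen next to a carbonyl group gives no change at the digits printed from compound 3 to compound 4 (within the scatter) in this assay, so among these compounds this end of the group does not shift clearance. The whole exchange on the aromatic carbon gives a 7.0-fold lower number from compound 1 to compound 4 (0.85 log units; beyond the scatter), matching a 7.0-fold lower number from compound 1 to compound 3 (0.85 log units; beyond the scatter) at the digits printed, which leaves the amide hydrogen as the change that tracks with the lower number. Nothing shown here explains why these steps take this size. From the compounds shown here alone, whether a longer chain or an amine on that oxygen would also leave clearance unmoved stays open.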